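The source may report more compounds than this note shows. Statements on the series, on what has been measured and on what is new or still open speak of the compounds shown alone.

Compound 1 `CC(=O)CCc1cc(C)c(Oc2cc(Nc3ccc(C#N)cc3)c(N)cc2C(F)(F)F)c(C)c1`: 0.16 ug/mL
Compound 2 `Cc1cc(CCC#N)cc(C)c1Oc1cc(Nc2ccc(C#N)cc2)c(N)cc1C(F)(F)F`: 0.24 ug/mL
Compound 3 `Cc1cc(/C=C/C#N)cc(C)c1Oc1cc(Nc2ccc(C#N)cc2)c(N)cc1C(F)(F)F`: 0.24 ug/mL

All three compounds were measured in a physicochemical assay for solubility, with a stated time of 4 h, at pH 7.4; a higher number here means a more soluble compound, a lower number a less soluble compound. Compound 3 stands level with compound 2 at the digits shown, and compound 1 lies within the scatter of both. The next compound, compound 4 `Cc1cc(C#N)cc(C)c1Oc1cc(Nc2ccc(C#N)cc2)c(N)cc1C(F)(F)F`, carries cyano in place of 2-cyanoethenyl on an aromatic carbon. For the measured compounds named here, no measured step makes this exact change, so the evidence is indirect. All three measured steps alter the group on that same aromatic carbon. They are a 1.5-fold higher number from compound 1 to compound 2 (0.18 log units; within the scatter), a 1.5-fold higher number from compound 1 to compound 3 (0.18 log units; within the scatter) and no change at the digits printed from compound 2 to compound 3 (within the scatter). None of these steps goes beyond the scatter, but none of them places cyano on the aromatic carbon itself. No step beyond the scatter is therefore expected in this assay, and the data offer no basis for a direction. The estimated step is no change at the digits printed from compound 3 to compound 4 (within the scatter). Compound 4 is expected at 0.24 ug/mL, with an estimated range of 0.1 ug/mL to 0.6 ug/mL.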

Compound 4, solubility: 0.26 ug/mL
Compound 4: middle estimate off by 1.1-fold (0.03 log units), on the low side; the range from low to high includes it.
By their numbers in this assay, from the lowest: compounds 1, 2, 3 and 4 (each within the scatter of the next).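

In this assay, for the compounds shown here, cyano placed directly on the aromatic carbon, the one change the earlier compounds did not show, gives a 1.1-fold higher number from compound 3 to compound 4 (0.03 log units; within the scatter), a 1.1-fold higher number from compound 2 to compound 4 (0.03 log units; within the scatter) and a 1.6-fold higher number from compound 1 to compound 4 (0.21 log units; within the scatter). The group at this carbon, meta to two methyl groups and para to a large group, can thus go from 2-cyanoethenyl, with 4 heavy atoms, to cyano, with 2 heavy atoms, with no step beyond the scatter, and all four compounds lie within the scatter of one another. Nothing available bears on why these numbers lie so close together.

Still open, as far as these compounds go, is whether a carboxylic acid or an amine on this same carbon would give a step beyond the scatter. Also open, from the compounds shown here alone, is how the number would respond if the trifluoromethyl group or the amino group on the shared core were exchanged for another group.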